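This account rests on a few compounds, and the source may have more. Where it says the series, first, only, none or still open, it means among the compounds named here.

Within the data shown here, compound 2 `COc1ccc(S(=O)(=O)N(C)c2ccc3[nH]c(-c4n[nH]c5ccccc45)cc3n2)cc1OC` gives 26600 nM in a functional assay on SMMC-7721 cells (Homo sapiens) for antiproliferative activity, read by MTT assay, with a stated time of 72 h (a lower number here means a stronger inhibitor, a higher number a weaker inhibitor), the larger of the two numbers so far, though the gap to compound 1 `Cc1ccc(S(=O)(=O)N(C)c2ccc3[nH]c(-c4n[nH]c5ccccc45)cc3n2)cc1`, which gives 16300 nM, lies within the scatter. Among the measured compounds shown here, the only measured step that changes the aryl group on the sulfonyl sulfur, a 1.6-fold higher number from compound 1 to compound 2 (0.21 log units; within the scatter), stays within the scatter. Compound 3 `CN(c1ccc2[nH]c(-c3n[nH]c4ccccc34)cc2n1)S(=O)(=O)c1ccc(OC(F)(F)F)cc1` differs from compound 2 by 4-(trifluoromethoxy)phenyl in place of 3,4-dimethoxyphenyl on a sulfonyl sulfur. Because a 1.6-fold higher number from compound 1 to compound 2 (0.21 log units; within the scatter) shows an aryl swap at this place barely moving this assay, the step of a 1.3-fold lower number from compound 2 to compound 3 (0.12 log units; within the scatter) is expected to stay within the scatter. Compound 3 is estimated at 20000 nM, range 7000 nM to 60000 nM.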

Compound 3, half-maximal inhibitory concentration: 7160 nM
For compound 3 the middle estimate is 2.8-fold (0.45 log units) above the measured one, within the range that was stated.
By their numbers in this assay, from the lowest: compound 3; then compounds 1 and 2 (each within the scatter of the next).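

The aryl group on a sulfonyl sulfur can move this assay beyond the scatter: 4-(trifluoromethoxy)phenyl in place of 3,4-dimethoxyphenyl gives a 3.7-fold lower number from compound 2 to compound 3 (0.57 log units; beyond the scatter), and trifluoromethoxy in place of methyl gives a 2.3-fold lower number from compound 1 to compound 3 (0.36 log units; beyond the scatter). Both steps are modest, yet they make compound 3 the strongest of the three. No measurement on hand bears on the reason for this gain.

Still open, going by these compounds, is whether the gain is specific to trifluoromethoxy or would also appear with a chlorine atom or a trifluoromethyl group. On these data alone, how an amine or a carboxylic acid on this aryl ring would fare also remains open.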